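This account rests on a few compounds, and the source may have more. Where it says the series, first, only, none or still open, it means among the compounds named here.

Compound 1 `COc1ccc2nc(-c3ccc(N/C=C\C(=O)c4ccc(OC)c(O)c4)c(C)c3)sc2c1` gives, in a functional assay on MDA-MB-231 cells (Homo sapiens) for antiproliferative activity, read by sulforhodamine B assay, with a stated time of 48 h (on this read-out higher numbers stand for weaker inhibition and lower numbers for stronger inhibition), a value of 14000 nM, the highest of the three numbers seen. Compound 2 `COc1cc(C(=O)/C=C\Nc2ccc(-c3nc4cc(OC)c(OC)c(OC)c4s3)cc2C)cc(OC)c1OC` gives 12900 nM in this assay, and compound 3 `COc1cc(OC)c2sc(-c3ccc(N/C=C\C(=O)c4ccc(OC)c(O)c4)cc3)nc2c1` gives 7610 nM; both numbers lie within the scatter of compound 1, so the three cannot be ordered. Compound 4 `COc1ccc2nc(-c3ccc(N/C=C\C(=O)c4ccc(OC)c([N+](=O)[O-])c4)c(C)c3)sc2c1` is the unmeasured partner of compound 1, differing by nitro in place of hydroxy on an aromatic carbon. For the measured compounds named here, no measured pair shows this change, and nothing in the three values points to a large effect, so compound 4 is expected to move by a 1.1-fold higher number from compound 1 to compound 4 (0.06 log units; within the scatter), a step of about none beyond the scatter, if anything toward a weaker result. Compound 4 is therefore estimated at 16000 nM, in a range from 5000 nM to 50000 nM.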

Compound 4, half-maximal inhibitory concentration: 17600 nM
Compound 4: middle estimate off by 1.1-fold (0.04 log units), on the low side; the measured number falls inside the stated range.
By their numbers in this assay, from the lowest: compounds 3, 2, 1 and 4 (each within the scatter of the next, the first and the last beyond it).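

In this assay, going from 3-hydroxy-4-methoxyphenyl to 4-methoxy-3-nitrophenyl gives a 1.3-fold higher number from compound 1 to compound 4 (0.10 log units; within the scatter). At this aromatic carbon, ortho to a methoxy group, hydroxy can thus give way to the larger nitro, with its hydrogen-bond donor gone, without a readable change in the number. No measurement shown bears on why this is so. From the compounds shown here alone, whether an amine or a carboxylic acid on this carbon would also leave the number within the scatter stays open. So does whether the same change behaves alike on the core of compound 3.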